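One Carbon Fewer in the Side Chain

This account rests on a few compounds, and the source may have more. Where it says the series, first, only, none or still open, it means among the compounds named here.

Compound 1 `N=C(S)CCn1nc(-c2cccs2)ccc1=O` and compound 2 `Cc1ccc(=O)n(CCCC(=N)S)n1` have been tested in a functional assay on the whole organism (stomach) with Rattus norvegicus as the target; on this read-out higher numbers stand for an effect only at larger amounts of compound and lower numbers for an effect already at smaller amounts. In this assay compound 1 gives 100 mg/kg. For compound 2 the result is only a limit, > 100 mg/kg, which is the limit of > 100 mg/kg in this assay, at which 1 of the 2 values shown sits. Compound 3 `Cc1ccc(=O)n(CCC(=N)S)n1` has not yet been measured. It differs from compound 2 by a group of 3 heavy atoms (1 carbon, 1 nitrogen, 1 sulfur; no ring) in place of a group of 4 heavy atoms (2 carbon, 1 nitrogen, 1 sulfur; no ring), on a saturated chain carbon, two bonds along the chain from an aromatic nitrogen. Within the data shown here, no measured pair shows this change, so the size of the step cannot be read from the data. The expected step is a number no higher from compound 2 to compound 3 (the limit leaves the size open), within the usual scatter. Compound 3 is estimated at 100 mg/kg, with a range from 40 mg/kg to 300 mg/kg.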

Compound 3, dose for half-maximal effect: 43.2 mg/kg
Compound 3: the middle estimate sits 2.3-fold (0.36 log units) above what was measured, within the range that was stated.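

In this assay, the group of 3 heavy atoms in place of the group of 4 heavy atoms gives an at least 2.3-fold lower number from compound 2 to compound 3 (0.36 log units; beyond the scatter), the first sign that the length of this side chain matters. The value of compound 2 is a limit, so this step has a known minimum but no known full size: the limit of > 100 mg/kg in this assay, at which 1 of the 3 values shown sits.

Methyl in place of thiophen-2-yl on an aromatic carbon gives a 2.3-fold lower number from compound 1 to compound 3 (0.36 log units; beyond the scatter), so the thiophen-2-yl group is not needed for an effect in this range.

Going by these compounds, it remains open whether an even shorter chain would lower the number further. Also open, on these data alone, is how an amine or a carboxylic acid would compare at the end of this chain.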